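The source may hold more compounds than are shown below. What is called first, only, known or untested is meant among the compounds shown, and "the series" means these compounds.

Within the data shown here, compound 2 `CN1CCC[C@H]1[C@H]1COc2ccc([N+](=O)[O-])cc2O1` gives the highest of the two numbers so far in an assay on membranes from HEK293 cells for displacement of a labelled ligand from Neuronal acetylcholine receptor; alpha3/beta4 (Homo sapiens), with a stated time of 5 min (on this read-out lower numbers stand for stronger inhibition and higher numbers for weaker inhibition), with compound 2 at 2100 nM; its nearest neighbour, compound 1 `CN1CCC[C@H]1[C@H]1COc2ccc(N)cc2O1`, gives 180 nM. Among the measured compounds shown here, the one measured step that bears on the next change is a 12-fold higher number from compound 1 to compound 2 (1.07 log units; beyond the scatter). Compound 3 `CN1CCC[C@H]1[C@H]1COc2ccc(O)cc2O1` differs from compound 2 by hydroxy in place of nitro on an aromatic carbon. The incoming hydroxy brings back a hydrogen-bond donor, as the amino of compound 1 had, so a downward step is expected, though not necessarily the full way back, with a 5.3-fold lower number from compound 2 to compound 3 (0.72 log units; beyond the scatter) estimated. Compound 3 is therefore expected to give about 400 nM in this assay, within 120 nM to 1300 nM.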

Compound 3, inhibition constant: 700 nM
For compound 3 the middle estimate is 1.8-fold (0.24 log units) below the measured one, and the stated range covers the measured number.
By their numbers in this assay, from the lowest: compound 1; then compound 3; then compound 2.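

On this aromatic carbon, hydroxy recovers part of the loss seen with nitro in this assay (a 3.0-fold lower number from compound 2 to compound 3 (0.48 log units; beyond the scatter)). It does not recover all of it (a 3.9-fold higher number from compound 1 to compound 3 (0.59 log units; beyond the scatter)), so amino and hydroxy are not interchangeable here, and the three groups are separated in order, each step beyond the scatter. Nothing shown accounts for this order. As far as these compounds go, whether a methoxy, an acetamide or a chlorine would fall within this range stays open. So does whether the order holds at the other aromatic carbons of the shared core.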